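Cytotoxicity of Ester Variants on a Shared Core

The source may hold more compounds than are shown below. What is called first, only, known or untested is meant among the compounds shown, and "the series" means these compounds.

Compound 1 `CCC(=O)OCCc1c(-c2ccccc2Cl)c2cc(Cl)ccc2[nH]c1=O`: 95000 nM
Compound 2 `CCCCCCCC(=O)OCCc1c(-c2ccccc2Cl)c2cc(Cl)ccc2[nH]c1=O`: 78000 nM

Compound 1 stands highest of the two numbers in an ADME assay on HepG2 2.2.15 cells (Homo sapiens) for cytotoxicity; on this read-out higher numbers stand for lower toxicity in this test and lower numbers for higher toxicity in this test; its nearest neighbour is compound 2, and the step of a 1.2-fold lower number from compound 1 to compound 2 (0.09 log units; within the scatter) lies within the scatter. Compound 3 `O=C(/C=C/c1ccccc1)OCCc1c(-c2ccccc2Cl)c2cc(Cl)ccc2[nH]c1=O` carries the change (2-phenylethenyl in place of ethyl on a carbonyl carbon), propanoyl becoming (2-phenylethenyl)carbonyl. For the measured compounds named here, the only measured step that bears on it, a 1.2-fold lower number from compound 1 to compound 2 (0.09 log units; within the scatter), also enlarged the ester side and hardly moved the read-out. A modestly lower number is nonetheless expected for compound 3, a 1.6-fold lower number from compound 1 to compound 3 (0.20 log units; within the scatter). Compound 3 is estimated at 60000 nM, with a range from 25000 nM to 120000 nM.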

Compound 3, half-maximal cytotoxic concentration: 230000 nM
For compound 3 the middle estimate is 3.8-fold (0.58 log units) below the measured one; the measured number lies above the stated range.
By their numbers in this assay, from the lowest: compounds 2 and 1 (each within the scatter of the next); then compound 3.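

On the carbonyl carbon, 2-phenylethenyl moved the read-out in this assay in a way that the longer saturated chain had not, in place of ethyl (a 2.4-fold higher number from compound 1 to compound 3 (0.38 log units; beyond the scatter)) and in place of heptyl (a 2.9-fold higher number from compound 2 to compound 3 (0.47 log units; beyond the scatter)). The position is therefore not indifferent to the group it carries, and this change points modestly toward lower toxicity in this test. Nothing available accounts for the shift.

The aromatic ring and the double bond enter together, so their shares remain unseparated. Going by these compounds, a saturated 2-phenylethyl group could divide them, and an amine on the ester side remains untested ground here.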